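The source may report more compounds than this note shows. Statements on the series, on what has been measured and on what is new or still open speak of the compounds shown alone.

Measured so far:
- compound 1, `Cc1ccc(OCC(=O)N(Cc2cccs2)CC(C)C)cc1`: 900 nM
- compound 2, `Cc1ccc(OCC(=O)N(Cc2cccs2)c2ccn[nH]2)cc1`: 0.2 nM
- compound 3, `Cc1ccc(OCC(=O)N(O)Cc2cccs2)cc1`: 8000 nM

All three share one core and differ only in the group on the amide-type nitrogen, tested in an assay on HEK293 cells for agonist activity at transient receptor potential cation channel subfamily M member 8 (Homo sapiens), read by fluorescence and calcium flux, with a stated time of 15 min; a higher number here means that more compound is needed for the effect, a lower number that less compound is needed. Compound 3 gives the highest number of the three; its nearest neighbour is compound 1, with an 8.9-fold higher number from compound 1 to compound 3 (0.95 log units; beyond the scatter), and the furthest is compound 2, with a 40000-fold higher number from compound 2 to compound 3 (4.60 log units; beyond the scatter).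

The next compound, compound 4 `Cc1ccc(OCC(=O)N(Cc2cccs2)c2cnccn2)cc1`, follows from compound 3 by pyrazin-2-yl in place of hydroxy on an amide-type nitrogen. The step that bears most directly on this is the one from a ring of the same kind back to hydroxy: a 40000-fold higher number from compound 2 to compound 3 (4.60 log units; beyond the scatter), a very large change. The step from isobutyl, an 8.9-fold higher number from compound 1 to compound 3 (0.95 log units; beyond the scatter), shows that hydroxy sits at the weak end of the set whatever replaces it. Within the data shown here, a six-membered aromatic ring with two hetero atoms entering in place of hydroxy is therefore expected to give a large move in this assay toward lower numbers, though the entering ring is not the one in compound 2 and carries no hydrogen-bond donor, so the full return to the number of compound 2 is not assumed. Compound 4 is expected to give 20 nM, within 2 nM to 300 nM, which would mean an expected step of a 400-fold lower number from compound 3 to compound 4 (2.60 log units; beyond the scatter).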

Compound 4, half-maximal effective concentration: 1240 nM
Compound 4: the middle estimate sits 62-fold (1.79 log units) below what was measured; measured number above the stated range.
By their numbers in this assay, from the lowest: compound 2; then compounds 1 and 4 (each within the scatter of the next); then compound 3.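

Placing an aromatic ring on the amide-type nitrogen is not enough by itself: pyrazin-2-yl in place of hydroxy gives only a 6.5-fold lower number from compound 3 to compound 4 (0.81 log units; beyond the scatter) and, set against isobutyl, shows a 1.4-fold higher number from compound 1 to compound 4 (0.14 log units; within the scatter) so that this ring and that saturated chain cannot be told apart at this position. The two rings, by contrast, lie far apart, with a 6200-fold higher number from compound 2 to compound 4 (3.79 log units; beyond the scatter) at the same place, so among the compounds shown the very low number of compound 2 goes with 1H-pyrazol-5-yl specifically and not with heteroaromatic rings on this nitrogen in general. Nothing at hand accounts for this gap between the two rings.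

As far as these compounds go, it remains open which difference between the two rings matters: ring size, the arrangement of the ring nitrogens, or the hydrogen on the ring nitrogen of 1H-pyrazol-5-yl. Phenyl, pyridin-2-yl, 1H-imidazol-2-yl and 1-methyl-1H-pyrazol-5-yl on the same nitrogen would begin to separate these possibilities, while an amine or a longer chain would test how far the non-aromatic end of the series extends.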